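The compounds below may be only part of what the source reports. "The series", "measured", "known", "first", "only" and "open" are said of these compounds alone.

Values in a functional assay on A549 cells (Homo sapiens) for antiproliferative activity, read by MTT assay, with a stated time of 72 h; on this read-out lower numbers stand for stronger inhibition and higher numbers for weaker inhibition:
- compound 1 `COc1cc2ncnc(Nc3cccc(Br)c3)c2cc1OCCCN1CCNCCNCCNCC1` gives 14700 nM in this assay
- compound 2 `COc1cc2ncnc(Nc3cccc(F)c3)c2cc1OCCCN1CCNCCNCCNCC1` gives > 50000 nM as a limit of the assay, not a number
- compound 3 `COc1cc2ncnc(Nc3cccc(Br)c3)c2cc1OCCCN1CCNCCNCC1` gives 34300 nM in this assay

Of the two true numbers, compound 3 holds the higher, 34300 nM in this assay. The ring change accounts for a 2.3-fold higher number from compound 1 to compound 3 (0.37 log units; beyond the scatter) but does not touch the aromatic position in question. Next is compound 4 `COc1cc2ncnc(Nc3cccc(C(F)(F)F)c3)c2cc1OCCCN1CCNCCNCC1`, which has trifluoromethyl in place of bromo on an aromatic carbon in the shared frame of compound 3.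

Among the compounds with values here, no measured step has trifluoromethyl entering. Within the data shown here, the nearest is the one step in which bromo leaves, with fluoro entering on the larger ring, an at least 3.4-fold higher number from compound 1 to compound 2 (0.53 log units; beyond the scatter) as a lower bound on its size. That gives a weak hint of a rise when bromo is lost, so a small upward move is expected in this assay, perhaps none beyond the scatter. The expected move is a 1.1-fold higher number from compound 3 to compound 4 (0.04 log units; within the scatter) and may reach the limit of > 50000 nM in this assay, at which 1 of the 3 values shown sits, as well.

The estimate for compound 4 is 38000 nM, with an expected range of 18000 nM to 50000 nM in this assay.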

Compound 4, half-maximal inhibitory concentration: 37300 nM
For compound 4 the middle estimate is 1.0-fold (0.01 log units) above the measured one, within the range that was stated.
By their numbers in this assay, from the lowest: compound 1; then compounds 3 and 4 (each within the scatter of the next). At a limit, above all of these: compound 2.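

In this assay, trifluoromethyl in place of bromo on the smaller ring gives a 1.1-fold higher number from compound 3 to compound 4 (0.04 log units; within the scatter), so on this ring the position accepts the larger group with no change beyond the scatter. The earlier step at this position, with fluoro entering on the larger ring, gave an at least 3.4-fold higher number from compound 1 to compound 2 (0.53 log units; beyond the scatter), so the loss of bromo alone does not carry a rise across the series, although the two steps sit on different rings and are not a direct comparison. Compound 2 stays a limit of the assay, not a number, and the size of its step stays open: the limit of > 50000 nM in this assay, at which 1 of the 4 values shown sits.

The ring step is shown with bromo only, so whether it holds with trifluoromethyl is open. From the compounds shown here alone, the effect of a nitrile or an amine at this position is also open.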